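Chloro in place of fluoro on compound 2

This account rests on a few compounds, and the source may have more. Where it says the series, first, only, none or still open, it means among the compounds named here.

Compound 1 `CC(=O)O[C@@H]1[C@H](OC(C)=O)[C@@H](CS(C)(=O)=O)O[C@H]1n1cnc2c(N)nc(Cl)nc21` gives 114000 nM
Compound 2 `CC(=O)O[C@@H]1[C@H](OC(C)=O)[C@@H](CN2C(=O)c3ccccc3C2=O)O[C@H]1n1cnc2c(N)nc(F)nc21` gives 129000 nM

Both values come from an ADME assay on L6 cells (Rattus norvegicus) for inhibition, read by resazurin assay, with a stated time of 72 h (a lower number here means a stronger inhibitor, a higher number a weaker inhibitor), and lie within the scatter of each other, so compound 2 stands level with compound 1 on these numbers. Compound 3 `CC(=O)O[C@@H]1[C@H](OC(C)=O)[C@@H](CN2C(=O)c3ccccc3C2=O)O[C@H]1n1cnc2c(N)nc(Cl)nc21` differs from compound 2 at one place (chloro in place of fluoro on an aromatic carbon): chloro in place of fluoro on an aromatic carbon. Going by the values given here, no measured pair shows this swap alone. Compound 1 already carries chloro, with a different side group, and its value (114000 nM) stays within the scatter of compound 2, so no change beyond the scatter is expected. The expected step is small (a 1.2-fold lower number from compound 2 to compound 3 (0.07 log units; within the scatter)). Compound 3 is estimated at 110000 nM (expected range 50000 nM to 220000 nM).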

Compound 3, half-maximal inhibitory concentration: 144000 nM
The estimate for compound 3 lay 1.3-fold (0.12 log units) below the measured number; measured number inside the range.
By their numbers in this assay, from the lowest: compounds 1, 2 and 3 (each within the scatter of the next).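

In this assay, chloro in place of fluoro on the aromatic carbon between two ring nitrogen atoms gives a 1.1-fold higher number from compound 2 to compound 3 (0.05 log units; within the scatter) and so leaves the number level, now in a direct pair. With chloro held fixed, the group of 11 heavy atoms in place of the group of 4 heavy atoms gives a 1.3-fold higher number from compound 1 to compound 3 (0.10 log units; within the scatter) and also leaves the number level. Nothing here offers an explanation for either result. Only two halogens appear at this carbon, so an amine or a methoxy group there remains an open case.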